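Benzodioxin amide replacing methoxyphenyl in a weak series

The compounds below may be only part of what the source reports. "The series", "measured", "known", "first", "only" and "open" are said of these compounds alone.

Measured compounds:
compound 1 `Cc1ccc(Nc2ncc(C(=O)Nc3cc(NC(=O)c4cccc(C(F)(F)F)c4)ccc3C)c(N(C)C)n2)cc1N`: 1210 nM
compound 2 `CNc1nc(Nc2ccc(C)c([N+](=O)[O-])c2)ncc1C(=O)Nc1cc(NC(=O)c2ccccc2OC)ccc1C`: > 10000 nM

In a functional assay on K562 cells (Homo sapiens) for antiproliferative activity, read by CellTiter-Glo and CCK-8 assay, with a stated time of 72 h (a lower number here means a stronger inhibitor of growth, a higher number a weaker inhibitor of growth), compound 1 gives 1210 nM. Compound 2 stands only at a limit of this assay, > 10000 nM, so no number is known for it; this is the limit of > 10000 nM in this assay, at which 1 of the 2 values shown sits. Compound 3 `CNc1nc(Nc2ccc(C)c([N+](=O)[O-])c2)ncc1C(=O)Nc1cc(NC(=O)c2ccc3c(c2)OCCO3)ccc1C` carries 2,3-dihydro-1,4-benzodioxin-6-yl in place of 2-methoxyphenyl on a carbonyl carbon. Among the compounds with values here, no measured step connects such a pair, and with compound 2 at a limit the size of the step cannot be anchored; a change of little consequence beyond the scatter, in either direction, is expected, as an at least 1.1-fold lower number from compound 2 to compound 3 (0.04 log units; that floor lies within the scatter). Compound 3 is therefore expected to give 9000 nM, with a range from 2500 nM to 30000 nM.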

Compound 3, concentration for 50% growth inhibition: 320 nM
Beside the measured number, compound 3's estimate is 28-fold (1.45 log units) above it; measured number outside the range, below it.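

Compound 2 and compound 3 differ only in the group on a carbonyl carbon whose other neighbour is an amide-type nitrogen, and this place proves far from indifferent in this assay: 2,3-dihydro-1,4-benzodioxin-6-yl in place of 2-methoxyphenyl gives an at least 31-fold lower number from compound 2 to compound 3 (1.49 log units; beyond the scatter). The full size of this large step cannot be given because one end of it is a limit: the limit of > 10000 nM in this assay, at which 1 of the 3 values shown sits.

The compounds shown leave open whether the non-aromatic ring with its two oxygens is needed for this gain. Going by these compounds, how an unsubstituted phenyl or a pyridine ring would read at the same carbonyl also remains open.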